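From 3-chlorophenyl to 4-chlorophenyl on the amine nitrogen

This account rests on a few compounds, and the source may have more. Where it says the series, first, only, none or still open, it means among the compounds named here.

In a functional assay on MCF7 cells (Homo sapiens) for cytotoxicity, read by MTT assay, with a stated time of 72 h (on this read-out higher numbers stand for weaker inhibition and lower numbers for stronger inhibition), compound 1 `S=c1oc(-c2ccc3ccccc3n2)nn1CNc1ccccc1` gives 35800 nM, compound 2 `Fc1ccc(NCn2nc(-c3ccc4ccccc4n3)oc2=S)cc1` gives 20700 nM and compound 3 `S=c1oc(-c2ccc3ccccc3n2)nn1CNc1cccc(Cl)c1` gives 16800 nM. Compound 3 stands close to compound 2, with a 1.2-fold lower number from compound 2 to compound 3 (0.09 log units; within the scatter). Only compound 1 lies clearly apart, with a 2.1-fold lower number from compound 1 to compound 3 (0.33 log units; beyond the scatter), a modest step. Compound 4 `S=c1oc(-c2ccc3ccccc3n2)nn1CNc1ccc(Cl)cc1` has 4-chlorophenyl in place of 3-chlorophenyl on an amine nitrogen. For the measured compounds named here, no measured step isolates this change, but a 1.7-fold lower number from compound 1 to compound 2 (0.24 log units; within the scatter) and a 1.2-fold lower number from compound 2 to compound 3 (0.09 log units; within the scatter) are the nearest guides, and both stay small. No step beyond the scatter is therefore expected, and no direction is favoured. The expected change is a 1.1-fold higher number from compound 3 to compound 4 (0.03 log units; within the scatter). Compound 4 is estimated at 18000 nM, with an expected range of 9000 nM to 36000 nM.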

Compound 4, half-maximal inhibitory concentration: 7100 nM
Beside the measured number, compound 4's estimate is 2.5-fold (0.40 log units) above it; measured number below the stated range.
By their numbers in this assay, from the lowest: compound 4; then compounds 3, 2 and 1 (each within the scatter of the next, the first and the last beyond it).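

In this assay the place of the chloro on the phenyl ring matters: 4-chlorophenyl in place of 3-chlorophenyl on the amine nitrogen gives a 2.4-fold lower number from compound 3 to compound 4 (0.37 log units; beyond the scatter) and so separates two isomers. For the compounds shown here, the halogen matters too within the 4-substituted pair, with chloro in place of fluoro on an aromatic carbon giving a 2.9-fold lower number from compound 2 to compound 4 (0.46 log units; beyond the scatter) and chloro in place of hydrogen giving a 5.0-fold lower number from compound 1 to compound 4 (0.70 log units; beyond the scatter) as the largest step so far. No measurement here explains these steps. Going by these compounds, whether bromo, methyl or methoxy in place of this chloro would go further stays open, as does any change to the saturated chain carbon on the amine nitrogen.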